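Series notes: substituent on the chain carbon at the aromatic nitrogen

The compounds below may be only part of what the source reports. "The series", "measured", "known", "first", "only" and "open" are said of these compounds alone.

Measured so far:
compound 1, `N#Cc1cccc(Cn2c(=O)n(C3OC(CO)[C@@H](O)[C@H]3O)c3nc(N)nc(O)c32)c1`, a functional assay (B cells) with Mus musculus as the target (on this read-out lower numbers stand for an effect already at smaller amounts and higher numbers for an effect only at larger amounts of compound), gives compound 1 3 uM
compound 2, `Cn1c(=O)n(C2OC(CO)[C@@H](O)[C@H]2O)c2nc(N)nc(O)c21`, in this assay compound 2 gives 10 uM

For the measured compounds named here, compound 2 stands at the higher of the two numbers; the only neighbour is compound 1, and the step of a 3.3-fold higher number from compound 1 to compound 2 (0.52 log units; beyond the scatter) runs beyond the scatter. Compound 3, `Nc1nc(O)c2c(n1)n(C1OC(CO)[C@@H](O)[C@H]1O)c(=O)n2C/C=C/c1ccccc1`, differs from compound 2 by 2-phenylethenyl in place of hydrogen on a saturated chain carbon bound to an aromatic nitrogen. Going by the values given here, the one step that bears on it is a 3.3-fold higher number from compound 1 to compound 2 (0.52 log units; beyond the scatter), where a ring-bearing group on that carbon went with the lower number. Reversing that direction, compound 3 is expected to move by a 3.3-fold lower number from compound 2 to compound 3 (0.52 log units; beyond the scatter). The estimate for compound 3 is 3 uM, within 1 uM to 10 uM.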

Compound 3, concentration for half-maximal effect: 103 uM
Estimate against measurement, compound 3: 34-fold (1.54 log units) below; the whole stated range lies below it.
By their numbers in this assay, from the lowest: compound 1; then compound 2; then compound 3.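

In this assay, a ring-bearing group on the saturated chain carbon bound to an aromatic nitrogen does not set the direction of change: 2-phenylethenyl in place of hydrogen gives a 10-fold higher number from compound 2 to compound 3 (1.01 log units; beyond the scatter), against a 3.3-fold higher number from compound 1 to compound 2 (0.52 log units; beyond the scatter) for the reverse kind of change. The two ring-bearing groups themselves lie far apart, with a 34-fold higher number from compound 1 to compound 3 (1.54 log units; beyond the scatter), so compound 2 falls between them. Nothing at hand accounts for this reversal.

Still open, as far as these compounds go, is whether the lower number of compound 1 goes with the nitrile or with the phenyl ring itself. Also open, from the compounds shown here alone, is how an unsubstituted benzyl group, an amine or a carboxylic acid at this position would read.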